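Decylthio Purine Series: Vero Cell Tolerance Examined

A few compounds are considered here, and "the series" means these few. Any claim that something is new, unique, unknown or untested is made for them only; others in the source may bear on it.

This account concerns a small group of decylthio-substituted purines tested in an ADME assay on Vero cells (Chlorocebus sabaeus) for cytotoxicity; a lower number here means that less compound is tolerated, a higher number that more compound is tolerated. For the measured compounds named here, compound 1 `CCCCCCCCCCSc1nc(N)nc2c1ncn2CC` is the only member with a firm number: in this assay compound 1 gives 12.3 ug/mL. Compound 2 `CCCCCCCCCCSc1ncnc2c1ncn2CC#N` has no number to stand on, since in this assay compound 2 is recorded as "not determined" (no result reported). Compound 3 `CCCCCCCCCCSc1nc(CC)nc2[nH]cnc12` is in the same position, with compound 3 recorded in this assay as "not determined" (no result reported). Going by the values given here, no step between two measured compounds is therefore available.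

The step from compound 2 to compound 4 `CCCCCCCCCCSc1ncnc2c1ncn2CC(=O)OC(C)(C)C` is a single change, (tert-butoxycarbonyl in place of cyano on a saturated chain carbon bound to an aromatic nitrogen). Among the compounds with values here, with no measured steps to lean on, the size of this step in this assay is unknown; the expectation is that it stays within the scatter, with no clear direction, and the only anchor is the value of compound 1 in this assay. Compound 4 is expected to give 15 ug/mL in this assay, with a range from 5 ug/mL to 45 ug/mL.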

Compound 4, half-maximal cytotoxic concentration: > 10 ug/mL
Compound 4: no number, only a limit; the forecaster's own chance of this, stated with the estimate: 25%; the middle value does not contradict the limit.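

No step can be read between compound 2 and compound 4; compound 2 has no reported result. Compound 4 gives only a limit, not a number: the limit of > 10 ug/mL in this assay, at which 1 of the 4 values shown sits.

In this assay the compounds shown leave open what replacing cyano with tert-butoxycarbonyl does to the tolerated concentration.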